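Changing the ring amine group from compound 2 to compound 3

The compounds below may be only part of what the source reports. "The series", "measured", "known", "first", "only" and "open" are said of these compounds alone.

Measured in an in vivo ADME assay on the whole organism (strain BALB/C) for pharmacokinetics, with Mus musculus as the target, read by LC-MS, at a dose of 10 mg/kg by the oral route; on this read-out lower numbers stand for lower oral bioavailability and higher numbers for higher oral bioavailability:
- compound 1 `CC(C)(C)N1C[C@H](C(=O)Nc2ccc(Cl)cc2)[C@@H](c2ccc(/C=C/C(=O)Nc3ccccc3N)cc2)C1`: 59%
- compound 2 `CC(C)(CO)N1C[C@H](C(=O)Nc2ccc(Cl)cc2)[C@@H](c2ccc(/C=C/C(=O)Nc3ccccc3N)cc2)C1`: 12%

Compound 2 stands lowest of the two, at 12%. Compound 3 `Nc1ccccc1NC(=O)/C=C/c1ccc([C@H]2CN(C3CCOCC3)C[C@@H]2C(=O)Nc2ccc(Cl)cc2)cc1` differs from it by oxan-4-yl in place of 1-(hydroxymethyl)-1-methylethyl on an amine nitrogen in a ring. Among the measured compounds shown here, the one measured step bearing on this is a number 47 percentage points lower from compound 1 to compound 2 (beyond the scatter), with hydroxy in place of hydrogen on a saturated chain carbon. Compound 3 has no such hydroxy, but its group also differs from that of compound 1. A rise beyond the scatter is therefore expected in this assay, smaller than that large drop. The estimated step is a number 23 percentage points higher from compound 2 to compound 3 (beyond the scatter). For compound 3 the expected value is 35%, within an estimated range of 15% to 55%.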

Compound 3, oral bioavailability: 23%
Estimate against measurement, compound 3: 12 percentage points above; the measured number falls inside the stated range.
By their numbers in this assay, from the lowest: compound 2; then compound 3; then compound 1.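

At the amine nitrogen in the ring, in this assay, oxan-4-yl in place of 1-(hydroxymethyl)-1-methylethyl gives a number 11 percentage points higher from compound 2 to compound 3 (beyond the scatter), so a group with no hydrogen-bond donor recovers only part of the loss seen with the hydroxy group. Oxan-4-yl in place of tert-butyl gives a number 36 percentage points lower from compound 1 to compound 3 (beyond the scatter), so low numbers at this position are not confined to the hydroxy-bearing group. No measured evidence here bears on the reason for these differences.

Open, on these data alone, is how a shorter alkyl chain such as isopropyl would read at this nitrogen. Also open, as far as these compounds go, is how a piperidin-4-yl group, which brings a second amine, would compare with oxan-4-yl.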